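A few compounds are considered here, and "the series" means these few. Any claim that something is new, unique, unknown or untested is made for them only; others in the source may bear on it.

In a functional assay on MIA PaCa-2 cells (Homo sapiens) for antiproliferative activity, read by sulforhodamine B assay, with a stated time of 48 h (on this read-out lower numbers stand for stronger inhibition and higher numbers for weaker inhibition), three compounds have been measured so far. Compound 1 `COc1cc(OC)c2sc(-c3ccc(N/C=C\C(=O)c4ccc(OC)c(O)c4)c(C)c3)nc2c1` gives 22100 nM, compound 2 `COc1cc(OC)c2sc(-c3ccc(N/C=C\C(=O)c4ccc(OC)c([N+](=O)[O-])c4)c(C)c3)nc2c1` gives 13900 nM, and compound 3 `COc1cc(C(=O)/C=C\Nc2ccc(-c3nc4cc(OC)c(OC)c(OC)c4s3)cc2)c(Br)c(OC)c1OC` gives 23200 nM. These numbers lie within the usual scatter of one another, so compound 2 stands level with the other two, not apart from them. Compound 4 `COc1ccc(C(=O)/C=C\Nc2ccc(-c3nc4cc(OC)c(OC)c(OC)c4s3)cc2C)cc1[N+](=O)[O-]` is compound 2 with one change on the core: methoxy in place of hydrogen on an aromatic carbon. Among the measured compounds shown here, the one measured step between closely matched compounds is a 1.6-fold lower number from compound 1 to compound 2 (0.20 log units; within the scatter), and it involves nitro in place of hydroxy at a different place, so it bears on this change only indirectly. For the measured compounds named here, no measured pair isolates the added methoxy. Compound 3 also carries that methoxy but differs elsewhere too, and its 23200 nM sits with the other values. No step beyond the scatter is therefore expected in this assay, in either direction. The expected result is a 1.1-fold higher number from compound 2 to compound 4 (0.03 log units; within the scatter). Compound 4 is estimated at 15000 nM, with an expected range from 6000 nM to 35000 nM.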

Compound 4, half-maximal inhibitory concentration: 23400 nM
For compound 4 the middle estimate is 1.6-fold (0.19 log units) below the measured one, within the range that was stated.
By their numbers in this assay, from the lowest: compounds 2, 1, 3 and 4 (each within the scatter of the next).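

In this assay, among the compounds shown here, the added methoxy gives a 1.7-fold higher number from compound 2 to compound 4 (0.23 log units; within the scatter) and this is the first measured pair that isolates methoxy in place of hydrogen at this position, ortho to two methoxy groups. In this one pair, the aromatic carbon carries the extra methoxy with no step beyond the usual scatter, so the change does not separate compound 4 from compound 2 in this assay. No available evidence accounts for this result.

As far as these compounds go, whether an amine, a carboxylic acid or a longer chain such as ethoxy at this position would give a step beyond the scatter remains open. A single pair also cannot show whether methoxy here would give the same result on the core of compound 1, which carries hydroxy instead of nitro.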